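The source may report more compounds than this note shows. Statements on the series, on what has been measured and on what is new or still open speak of the compounds shown alone.

Three compounds share one core and differ only in the aryl group on an amide-type nitrogen. Compound 1 `O=C(Nc1cccc([N+](=O)[O-])c1)N[C@H]1CC[C@H](Oc2ccc(F)cc2)CC1` gives 6700 nM in a functional assay on CRL2813 cells (Homo sapiens) for cytotoxicity, read by sulforhodamine B assay, with a stated time of 5 days; a lower number here means a stronger inhibitor, a higher number a weaker inhibitor. Compound 2 `O=C(Nc1ccc([N+](=O)[O-])cc1)N[C@H]1CC[C@H](Oc2ccc(F)cc2)CC1` gives 2300 nM in this assay, and a 2.9-fold lower number from compound 1 to compound 2 (0.46 log units; beyond the scatter). Compound 3 `O=C(Nc1ccccc1I)N[C@H]1CC[C@H](Oc2ccc(F)cc2)CC1` reaches only the limit of > 20000 nM in this assay, so for compound 3 no number is known. Compound 3 alone sits at the limit of > 20000 nM in this assay, at which 1 of the 3 values shown sits. an at least 2.9-fold higher number from compound 1 to compound 3 (0.47 log units; beyond the scatter), and an at least 8.6-fold higher number from compound 2 to compound 3 (0.93 log units; beyond the scatter). Compound 4 `CSc1cccc(NC(=O)N[C@H]2CC[C@H](Oc3ccc(F)cc3)CC2)c1` differs from compound 3 in one place: 3-(methylsulfanyl)phenyl in place of 2-iodophenyl on an amide-type nitrogen. The two steps leading into compound 3, both beyond the scatter, bear on this change, and the move away from 2-iodophenyl is expected to run the other way. The expected step is an at least 2.5-fold lower number from compound 3 to compound 4 (0.39 log units; beyond the scatter). Compound 4 is therefore estimated at 8000 nM in this assay, within 2500 nM to 25000 nM.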

Compound 4, half-maximal inhibitory concentration: 11100 nM
Beside the measured number, compound 4's estimate is 1.4-fold (0.14 log units) below it; the measured number falls inside the stated range.
By their numbers in this assay, from the lowest: compound 2; then compounds 1 and 4 (each within the scatter of the next). At a limit, above all of these: compound 3.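

In this assay, for the compounds shown here, methylsulfanyl and nitro on this aromatic carbon cannot be told apart: a 1.7-fold higher number from compound 1 to compound 4 (0.22 log units; within the scatter), so nitro is not the only group compatible with this value range. The 4-nitrophenyl group still holds a gap over the new aryl group: a 4.8-fold higher number from compound 2 to compound 4 (0.68 log units; beyond the scatter). The other step, an at least 1.8-fold lower number from compound 3 to compound 4 (0.25 log units; that floor lies within the scatter), rests on a limit and not a number: the limit of > 20000 nM in this assay, at which 1 of the 4 values shown sits.

As far as these compounds go, what an amine, a carboxylic acid or a methoxy group would give on this aromatic carbon stays open. So does what 4-(methylsulfanyl)phenyl would give beside 4-nitrophenyl.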